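This account rests on a few compounds, and the source may have more. Where it says the series, first, only, none or still open, it means among the compounds named here.

Among the measured compounds shown here, compound 1 `COc1ccc(C2=NN(C3=NC(=O)/C(=C4\C(=O)Nc5ccccc54)S3)C(c3ccc(OC)cc3)C2)cc1` gives 92200 nM in a functional assay on cells (Cancer cell lines, Homo sapiens) for cytotoxicity, read by sulforhodamine B assay, with a stated time of 48 h (on this read-out lower numbers stand for stronger inhibition of growth and higher numbers for weaker inhibition of growth), the highest of the three numbers measured so far. Compound 2 `COc1ccc(C2=NN(C3=NC(=O)/C(=C4\C(=O)Nc5ccc(Br)cc54)S3)C(c3ccc(OC)cc3)C2)cc1` gives 240 nM in this assay, and compound 3 `COc1ccc(C2CC(c3ccc4ccccc4c3)=NN2C2=NC(=O)/C(=C3\C(=O)Nc4ccccc43)S2)cc1` gives 970 nM in this assay. The step of a 380-fold lower number from compound 1 to compound 2 (2.58 log units; beyond the scatter) comes from bromo in place of hydrogen on an aromatic carbon; the step of a 95-fold lower number from compound 1 to compound 3 (1.98 log units; beyond the scatter) comes from naphthalen-2-yl in place of 4-methoxyphenyl on a carbon with a double bond to nitrogen. Both steps are large and both lower the number.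

Compound 4 `COc1ccc(C2=NN(C3=NC(=O)/C(=C4\C(=O)Nc5ccccc54)S3)C(c3ccc(Cl)cc3)C2)cc1` differs from compound 1 by chloro in place of methoxy on an aromatic carbon, on a six-membered aromatic ring of carbon only; read one bond further out, the change is 4-methoxyphenyl to 4-chlorophenyl. Neither measured step touches this ring: the bromo of compound 2 sits on a different aromatic carbon, and compound 3 alters the other aryl. For the measured compounds named here, there is no direct precedent for the change. The two measured steps from compound 1 show that single changes to it move the number far, each time downward, so a drop is expected here too, but a smaller and less certain one than either. Compound 4 is expected to give 10000 nM in this assay, with a range of 1000 nM to 70000 nM. That estimate means an expected step of a 9.2-fold lower number from compound 1 to compound 4 (0.96 log units; beyond the scatter).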

Compound 4, concentration for 50% growth inhibition: 100000 nM
For compound 4 the middle estimate is 10-fold (1.00 log units) below the measured one; measured number outside the range, above it.
By their numbers in this assay, from the lowest: compound 2; then compound 3; then compounds 1 and 4 (each within the scatter of the next).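

With chloro in place of methoxy on this aromatic carbon, para to a large group, this assay gives a 1.1-fold higher number from compound 1 to compound 4 (0.04 log units; within the scatter), so this exchange does not separate the two compounds. Not every single change to compound 1 therefore registers in this read-out: the bromo and naphthalen-2-yl changes give large steps, while the 4-methoxyphenyl to 4-chlorophenyl change does not. No measurement on hand bears on the reason for this result.

As far as these compounds go, whether an amine or a carboxylic acid at this place would also fall within the scatter of compound 1 remains open. Also open, from the compounds shown here alone, is whether 4-chlorophenyl in place of 4-methoxyphenyl would read the same way on the bromo-bearing compound 2, whose number lies far lower.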